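Thiophen-2-yl urea after naphthalen-1-yl: growth inhibition notes

This account rests on a few compounds, and the source may have more. Where it says the series, first, only, none or still open, it means among the compounds named here.

Compound 1 `O=C(Nc1ccc(Nc2ncnc3c2OCCN3)cc1)Nc1ccc(C(F)(F)F)cc1` - 10000 nM
Compound 2 `O=C(Nc1ccc(Nc2ncnc3c2OCCN3)cc1)Nc1cccc2ccccc12` - > 10000 nM (a limit)
Compound 3 `O=C(Nc1ccc(Nc2ncnc3c2OCCN3)cc1)Nc1cccs1` - not yet measured

In a functional assay on BaF3 cells (Mus musculus) for inhibition, read by MTT assay, with a stated time of 3 days (a higher number here means a weaker inhibitor of growth, a lower number a stronger inhibitor of growth), compound 1 gives 10000 nM as a number. Compound 2 stands at > 10000 nM, which is a limit of the assay. The change to compound 3 is thiophen-2-yl in place of naphthalen-1-yl on an amide-type nitrogen. Going by the values given here, the one measured step at this place is a number no lower from compound 1 to compound 2 (the limit leaves the size open), and it offers no readable size. Among the compounds with values here, compound 1 at 10000 nM is the only number to lean on, so weak growth inhibition is expected to persist. The expected step is a number no higher from compound 2 to compound 3 (the limit leaves the size open), none beyond the scatter. Compound 3 is expected at 10000 nM, within an estimated range of 4000 nM to 20000 nM.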

Compound 3, concentration for 50% growth inhibition: > 10000 nM
Compound 3 gave a limit, no number; the forecaster's own chance of this, stated with the estimate: 65%; the middle value sits exactly at the limit.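

In this assay compound 3 gives > 10000 nM, a limit of the assay and not a number. Thiophen-2-yl, one five-membered aromatic ring with a sulfur, therefore joins naphthalen-1-yl at the limit on the amide-type nitrogen, so going from two six-membered rings to this smaller ring yields no number. The steps to compound 3 cannot be read in size, and the series is bounded here: the limit of > 10000 nM in this assay, at which 2 of the 3 values shown sit.

From the compounds shown here alone, how far compound 2 and compound 3 lie past the limit stays open. Thiophen-2-yl in place of 4-(trifluoromethyl)phenyl on the amide-type nitrogen gives a number no lower from compound 1 to compound 3 (the limit leaves the size open).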